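Selenol to Methylsulfanyl on a Shared Quinazoline-Type Core

The compounds below may be only part of what the source reports. "The series", "measured", "known", "first", "only" and "open" are said of these compounds alone.

Compound 1 `Sc1nc(NCc2ccccc2)c2ccccc2n1` gives 15200 nM in a functional assay on HTB-54 cells (Homo sapiens) for cytotoxicity, read by MTT assay, with a stated time of 72 h; on this read-out lower numbers stand for stronger inhibition of growth and higher numbers for weaker inhibition of growth.
Compound 2 `[SeH]c1nc(NCc2ccccc2)c2ccccc2n1` gives 31200 nM in this assay.

Of these two numbers, compound 2 stands highest; its nearest neighbour is compound 1, and the step is a 2.1-fold higher number from compound 1 to compound 2 (0.31 log units; beyond the scatter), a swap of one sulfur atom for one selenium atom on an aromatic carbon.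

Compound 3 `CSc1nc(NCc2ccccc2)c2ccccc2n1` is the next case. The change from compound 2 is a group of 2 heavy atoms (1 carbon, 1 sulfur; no ring) in place of one selenium atom, on an aromatic carbon. Going by the values given here, only one measured step bears on it: a 2.1-fold higher number from compound 1 to compound 2 (0.31 log units; beyond the scatter), which tells what selenium in place of sulfur did, so returning to sulfur should roughly undo that modest rise. Among the compounds with values here, no measured pair shows what the added methyl does, so that part is open. The expected step is therefore a 2.1-fold lower number from compound 2 to compound 3 (0.32 log units; beyond the scatter), a modest move to a lower number, landing near compound 1. The estimate for compound 3 is 15000 nM, with a range from 5000 nM to 45000 nM.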

Compound 3, concentration for 50% growth inhibition: 37900 nM
For compound 3 the middle estimate is 2.5-fold (0.40 log units) below the measured one, and the stated range covers the measured number.
By their numbers in this assay, from the lowest: compound 1; then compounds 2 and 3 (each within the scatter of the next).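

At this carbon between two ring nitrogen atoms, the sulfur's hydrogen can't be replaced without some cost: methyl in place of hydrogen on the sulfur gives a 2.5-fold higher number from compound 1 to compound 3 (0.40 log units; beyond the scatter) in this assay, a modest weakening of growth inhibition. Methylsulfanyl in place of selenium gives a 1.2-fold higher number from compound 2 to compound 3 (0.08 log units; within the scatter), so compound 2 and compound 3 cannot be told apart here, while compound 1 keeps the lowest number of the three. Nothing available explains either step.

The compounds shown leave open whether a longer chain on the sulfur, such as ethylsulfanyl, would move the number further, and whether methyl on the selenium would act as methyl on the sulfur does. They also leave open how an amine or a hydroxyl group on this carbon would compare with the sulfur of compound 1.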